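The source may hold more compounds than are shown below. What is called first, only, known or untested is meant among the compounds shown, and "the series" means these compounds.

In a functional assay on NCI-H460 cells (Homo sapiens) for cytotoxicity, read by sulforhodamine B assay, with a stated time of 3 days (a lower number here means a stronger inhibitor, a higher number a weaker inhibitor), compound 2 `OCc1cn(Cc2ccc(Cl)cc2)c2ccccc12` gives 16 nM and compound 3 `Cc1cccc(Cn2cc(CO)c3ccccc32)c1` gives 31 nM so the two lie within the scatter of each other. Compound 1 `CC(C)Cn1cc(C=O)c2ccccc21` gives 1990 nM as a much higher number than compound 2, beyond the scatter. Compound 4 `O=[N+]([O-])c1ccc(Cn2cc(CO)c3ccccc32)cc1` departs from compound 2 by one change nitro in place of chloro on an aromatic carbon with nitro in place of chloro on an aromatic carbon, para to a large group. Among the measured compounds shown here, no measured pair differs in one place, so the data offer no direct guide to this change. A modest rise in the number is expected, and the estimated step of a 2.5-fold higher number from compound 2 to compound 4 (0.40 log units; beyond the scatter) is only a rough expectation. For compound 4 an expected value of 40 nM is estimated, with 12 nM to 130 nM as the likely range.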

Compound 4, half-maximal inhibitory concentration: 79 nM
Compound 4: the middle estimate sits 2.0-fold (0.30 log units) below what was measured; the range from low to high includes it.
By their numbers in this assay, from the lowest: compounds 2 and 3 (each within the scatter of the next); then compound 4; then compound 1.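

In this assay, among the compounds shown here, nitro in place of chloro on an aromatic carbon, para to a large group, gives a 4.9-fold higher number from compound 2 to compound 4 (0.69 log units; beyond the scatter), the first step that changes one place only. The position is therefore sensitive to the identity of its substituent, and compound 4 keeps a value of 79 nM with nitro there. No measured evidence bears on the origin of this step.

With only chloro and nitro compared at this position, the effect of group size or hydrogen-bond acceptors cannot be separated. An amine or a methoxy group at the same carbon would test this.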